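Hydrazone series: pyridin-3-yl for 4-methylphenyl on the carbonyl

The compounds below may be only part of what the source reports. "The series", "measured", "known", "first", "only" and "open" are said of these compounds alone.

Measured compounds:
compound 1 `O=C(N/N=C/C1=C(Cl)c2ccccc2CCC1)c1ccccc1`: in a functional assay on HeLa cells (Homo sapiens) for inhibition, read by sulforhodamine B assay, with a stated time of 48 h (a higher number here means a weaker inhibitor of growth, a lower number a stronger inhibitor of growth), compound 1 gives > 100000 nM, a limit of the assay.
compound 2 `Cc1ccc(C(=O)N/N=C/C2=C(Cl)c3cc(C)c(C)cc3CCC2)cc1`: in this assay compound 2 gives > 100000 nM, likewise a limit.

Compound 2 thus stands at the limit, with no number of its own, and both values shown sit there (the limit of > 100000 nM in this assay, at which 2 of the 2 values shown sit). Compound 3 `Cc1cc2c(cc1C)C(Cl)=C(/C=N/NC(=O)c1cccnc1)CCC2` differs from compound 2 by pyridin-3-yl in place of 4-methylphenyl on a carbonyl carbon. Among the measured compounds shown here, no measured step between any two compounds exists to size this change, so in this assay no movement beyond the scatter is expected, and compound 3 is expected most likely to stay at the limit. The step from compound 2 to compound 3 is expected to be a number no higher from compound 2 to compound 3 (the limit leaves the size open). For compound 3 the estimate is 100000 nM, within 25000 nM to 300000 nM.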

Compound 3, concentration for 50% growth inhibition: 650 nM
Compound 3: middle estimate off by 150-fold (2.19 log units), on the high side, and the stated range ends above it.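

In this assay, pyridin-3-yl in place of 4-methylphenyl on a carbonyl carbon gives an at least 150-fold lower number from compound 2 to compound 3 (2.18 log units; beyond the scatter). This position can therefore move the series off the limit, and compound 3 is the first compound shown with a number of its own. The full size of the step stays open because compound 2 sits at a limit: the limit of > 100000 nM in this assay, at which 2 of the 3 values shown sit.

From the compounds shown here alone, whether the shift follows the ring nitrogen or the loss of the methyl remains open. Also open, going by these compounds, are how pyridin-4-yl would read at this carbonyl and whether pyridin-3-yl acts alike on the core of compound 1.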